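Hydroxy for methoxy in a pyrazolyl-phenyl urea cytotoxicity series

This account rests on a few compounds, and the source may have more. Where it says the series, first, only, none or still open, it means among the compounds named here.

Compound 1 `O=C(Nc1cccc(-n2cc(-c3ccncc3)c(-c3ccc(Cl)c(O)c3)n2)c1)Nc1cccc(C(F)(F)F)c1` and compound 2 `COc1cc(-c2nn(-c3cccc(NC(=O)Nc4ccc(Cl)c(Cl)c4)c3)cc2-c2ccncc2)ccc1Cl` have been run in a functional assay on HCT-116 cells (Homo sapiens) for inhibition, read by sulforhodamine B assay, with a stated time of 48 h; on this read-out lower numbers stand for higher toxicity in this test and higher numbers for lower toxicity in this test. In this assay compound 1 reaches only the assay limit of > 32500 nM. Compound 2 likewise gives only a limit in this assay, > 50000 nM. Going by the values given here, compound 2 therefore stands at a limit rather than a number, and the one further value shown for the series is also a limit, as recorded in the limit of > 32500 nM in this assay, at which 1 of the 2 values shown sits, and (the limit of > 50000 nM in this assay, at which 1 of the 2 values shown sits); no ranking between the two compounds can be drawn from this.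

Compound 3 `O=C(Nc1cccc(-n2cc(-c3ccncc3)c(-c3ccc(Cl)c(O)c3)n2)c1)Nc1ccc(Cl)c(Cl)c1` is not yet measured in this assay. It differs from compound 2 in one place: hydrogen in place of methyl on an oxygen on an aromatic ring, methoxy becoming hydroxy on the 4-chloro-3-methoxyphenyl to give 4-chloro-3-hydroxyphenyl. Compound 1 already carries the hydroxy variant and sits at a limit, so for this step no shift beyond the scatter is expected, and compound 3 is expected to remain at or beyond the assay ceiling, with the step from compound 2 to compound 3 estimated as a step that the limit leaves unreadable from compound 2 to compound 3. Compound 3 is accordingly estimated at 60000 nM, within 20000 nM to 150000 nM.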

Compound 3, concentration lethal to 50% of the cells: > 32500 nM
Compound 3: only a limit was reported; the forecaster's own chance of this, stated with the estimate: 80%; the middle value lies beyond the limit too.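

Compound 3 gives only a limit in this assay, as do compound 1 and compound 2, so neither the step from compound 2 to compound 3 nor the step from compound 1 to compound 3 can be read. The compounds shown leave open whether hydroxy in place of methoxy, or 3,4-dichlorophenyl in place of 3-(trifluoromethyl)phenyl, changes toxicity in this assay.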